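A few compounds are considered here, and "the series" means these few. Any claim that something is new, unique, unknown or untested is made for them only; others in the source may bear on it.

Measured so far in a functional assay on the whole organism with Mus musculus as the target, in the rotarod test; a higher number here means that more compound is needed for the effect, a lower number that less compound is needed:

compound 1 `CCN(C)C(=O)/C=C1\CCc2c(F)cc(F)cc21` — 73 mg/kg
compound 2 `NC(=O)/C=C1\CCc2cc(F)c(F)cc21` — 82 mg/kg

Compound 1 shows the lower of the two numbers in this assay, but its nearest neighbour, compound 2, gives 82 mg/kg, and the gap between the two lies within the scatter of repeated measurements, so no order between compound 1 and compound 2 can be read from these numbers. Among the compounds with values here, the two also differ in more than one place, so no single step between measured compounds is available.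

Compound 3 `CC(C)NC(=O)/C=C1\CCc2c(F)cc(F)cc21` is the next compound for this assay. Against compound 1 it carries one change at the carbonyl carbon: isopropylamino in place of ethyl(methyl)amino on a carbonyl carbon. The leaving and entering groups hold the same count of heavy atoms; the entering group brings one hydrogen-bond donor where the leaving group had none.

Within the data shown here, with no comparable step among the measured compounds, there is nothing to scale the effect of this change. The expected outcome for compound 3 is a number close to that of compound 1, with a step of a 1.0-fold lower number from compound 1 to compound 3 (0.02 log units; within the scatter) that is not expected to exceed the scatter in either direction. The estimate for compound 3 in this assay is therefore 70 mg/kg, within a range from 35 mg/kg to 140 mg/kg.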

Compound 3, dose for half-maximal effect: 76 mg/kg
Compound 3: the middle estimate sits 1.1-fold (0.04 log units) below what was measured, within the range that was stated.
By their numbers in this assay, from the lowest: compounds 1, 3 and 2 (each within the scatter of the next).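

In this assay, within the data shown here, the exchange of ethyl(methyl)amino for isopropylamino on a carbonyl carbon gives a 1.0-fold higher number from compound 1 to compound 3 (0.02 log units; within the scatter) and is the first single-place step available. The two groups hold the same count of heavy atoms and the entering group brings one hydrogen-bond donor, yet this step cannot be told apart from repeat scatter, so this particular exchange at this position gives no readable difference in the dose needed in the rotarod read-out; one step on one core supports no wider statement about the position. Nothing measured on these compounds bears on why the number holds here, and no explanation can be offered for the result.

Still open, from the compounds shown here alone, is whether a group of another size or type on the same carbonyl carbon, such as a hexylamino chain, a morpholine ring or the hydroxyl of a carboxylic acid, would give a step beyond the scatter. Also open, going by these compounds, is whether the hydrogen-bond donor count matters at all on this core, since a single exchange that also rearranges the carbon chain cannot separate the two.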